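From benzyl to allyl near the limit of a toxicity read-out

This account rests on a few compounds, and the source may have more. Where it says the series, first, only, none or still open, it means among the compounds named here.

In a functional assay on CEM-SS cells (Homo sapiens) for inhibition, read by thymidine incorporation (on this read-out higher numbers stand for lower toxicity in this test and lower numbers for higher toxicity in this test), two compounds built on a shared core have been measured so far. Compound 1 (`C=CCNC(C)Cn1c(S)nc2ccccc21`), which carries allyl, gives > 100000 nM in this test, and that figure is a limit of the assay, not a number. Within the data shown here, compound 2 (`CC(Cn1c(S)nc2ccccc21)N(C)Cc1ccccc1`) gives 79000 nM as the only actual number so far, which leaves it as the single fixed point on the scale.

Compound 3 (`C=CCN(C)C(C)Cn1c(S)nc2ccccc21`) has not yet been measured. Going from compound 2 to compound 3 exchanges benzyl for allyl (vinyl in place of phenyl on a saturated chain carbon bound to an amine nitrogen), that is, vinyl in place of phenyl on a saturated chain carbon bound to an amine nitrogen. The expectation leans on compound 1, the other allyl compound, which sits at its limit of > 100000 nM in this test. In this assay the expected change is small, towards higher numbers and probably not beyond the scatter. The estimated step (a 1.3-fold higher number from compound 2 to compound 3 (0.10 log units; within the scatter)) would mean slightly lower toxicity at most. For compound 3 the estimate is 100000 nM with an expected range from 45000 nM to 200000 nM in this test.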

Compound 3, half-maximal cytotoxic concentration: > 100000 nM
Compound 3: only a limit was reported; the forecaster's own chance of this, stated with the estimate: 60%; the middle value lies on the limit itself.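

With compound 3, this assay gains a comparison that changes only one place, and the benzyl to allyl change on a saturated chain carbon bound to an amine nitrogen reads as an at least 1.2-fold higher number from compound 2 to compound 3 (0.10 log units; that floor lies within the scatter). That floor does not establish a change beyond the scatter, but it does show that compound 3, which keeps the methyl on the amine nitrogen of compound 2, carries allyl and also ends at the limit rather than at a number. The step that puts methyl in place of hydrogen on the amine nitrogen, from compound 1 to compound 3, cannot be read, because both values are limits and the read-out gives no size beyond them: the limit of > 100000 nM in this assay, at which 2 of the 3 values shown sit.

From the compounds shown here alone, how far compound 3 really lies from compound 2 stays open, so the true size of the benzyl to allyl change could still be small or large. Going by these compounds, it is also open whether a saturated propyl chain or a longer chain on the same amine nitrogen would stay at the limit in this assay or give a number, as the benzyl of compound 2 does.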